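This account rests on a few compounds, and the source may have more. Where it says the series, first, only, none or still open, it means among the compounds named here.

Compound 1 `FC(F)(F)c1cccc(-c2nc3cnc(Nc4cnccn4)cc3[nH]2)c1`, compound 2 `FC(F)(F)c1ccc(Nc2cc3[nH]c(-c4cccc(C(F)(F)F)c4)nc3cn2)nc1` and compound 3 `O=C(O)c1ccc(Nc2cc3[nH]c(-c4cccc(C(F)(F)F)c4)nc3cn2)nc1` share one core and differ in the group on a nitrogen on an aromatic ring. Among the measured compounds shown here, in a physicochemical assay for solubility, using the shake flask method, in phosphate buffer, measured as kinetic solubility, with a stated time of 20 h, at pH 6.5 (a higher number here means a more soluble compound, a lower number a less soluble compound), compound 3 gives 6000 nM, the only number in the set. Compound 1 gives < 5000 nM, a limit of this assay. Compound 2 likewise gives < 5000 nM, a limit. Compound 3 thus stands as the sole readable point, with the limit of < 5000 nM in this assay, at which 2 of the 3 values shown sit, beneath the other two. The steps of an at least 1.2-fold higher number from compound 1 to compound 3 (0.07 log units; that floor lies within the scatter) and an at least 1.2-fold higher number from compound 2 to compound 3 (0.07 log units; that floor lies within the scatter) are floors only, and a step that the two limits leave unreadable from compound 1 to compound 2 cannot be read. Compound 4 `O=C(O)c1ccnc(Nc2cc3[nH]c(-c4cccc(C(F)(F)F)c4)nc3cn2)c1` carries 4-carboxypyridin-2-yl in place of 5-carboxypyridin-2-yl on a nitrogen on an aromatic ring, the same atoms joined differently. For the measured compounds named here, no measured step tracks such a rearrangement, so nothing beyond the scatter is expected. The estimated step is no change at the digits printed from compound 3 to compound 4 (within the scatter). Compound 4 is expected to give 6000 nM, between 2500 nM and 15000 nM.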

Compound 4, solubility: < 5000 nM
Compound 4: no number, only a limit (the forecaster's own chance of this, stated with the estimate: 30%); middle value at least 1.2-fold (0.07 log units) from the limit.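

The rearrangement to 4-carboxypyridin-2-yl in place of 5-carboxypyridin-2-yl gives an at least 1.2-fold lower number from compound 3 to compound 4 (0.07 log units; that floor lies within the scatter), so carrying the carboxy group does not by itself secure a readable number in this assay, although that floor lies within the scatter. Compound 4 gives < 5000 nM, a limit, and the set now gathers at one point: the limit of < 5000 nM in this assay, at which 3 of the 4 values shown sit. The steps to compound 4 from compound 1 and compound 2 cannot be read.

Going by these compounds, whether compound 4 truly differs from compound 3 beyond the scatter stays open. So does whether a primary amide or an amine in place of carboxy would give a number clear of the limit.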